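This account rests on a few compounds, and the source may have more. Where it says the series, first, only, none or still open, it means among the compounds named here.

Measured so far in a functional assay on HEK293 cells for agonist activity at G-protein coupled receptor 39 (Homo sapiens), read by scintillation proximity assay and inositol phosphate accumulation, with a stated time of 75 min; on this read-out lower numbers stand for an effect already at smaller amounts and higher numbers for an effect only at larger amounts of compound:
compound 1 `Cc1nn(-c2ncnc3nc[nH]c23)c2c1C(C(=O)NCc1ccc(F)cc1)CC(=O)N2` gives 1220 nM
compound 2 `Cc1cc(C)n(CCOC2CC(=O)Nc3c2c(C)nn3-c2ncnc3nc[nH]c23)n1` gives 2000 nM
compound 3 `Cc1nn(-c2ncnc3nc[nH]c23)c2c1C(OCc1ccccc1C#N)CC(=O)N2` gives 127 nM

Compound 2 stands at the highest of the three numbers. Compound 1 is its nearest neighbour and sits within the scatter of it, so no order can be read between those two. Compound 3 lies furthest off: a 16-fold lower number from compound 2 to compound 3 (1.20 log units; beyond the scatter).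

Compound 4 `Cc1nn(-c2ncnc3nc[nH]c23)c2c1C(OCc1ccc(C#N)cc1)CC(=O)N2` is not yet measured. It differs from compound 2 as follows: 4-cyanophenyl in place of (3,5-dimethyl-1H-pyrazol-1-yl)methyl on a saturated chain carbon bound to an oxygen on a saturated carbon.

Within the data shown here, the only measured step that bears on this change is the one from compound 2 to compound 3, where 2-cyanophenyl entered at the same place on a saturated chain carbon bound to an oxygen on a saturated carbon; that step was large, a 16-fold lower number from compound 2 to compound 3 (1.20 log units; beyond the scatter). Among the measured compounds shown here, compound 4 carries the same ring type with the nitrile as 4-cyanophenyl instead; no measured pair compares 2-cyanophenyl with 4-cyanophenyl, so the direction of the step is better supported than its size. In this assay a clearly lower number than that of compound 2 is expected for compound 4. For the measured compounds named here, the expected step, taken smaller than the one measured to compound 3 to allow for the untested ring substitution pattern, is a 6.7-fold lower number from compound 2 to compound 4 (0.82 log units; beyond the scatter). Compound 4 is thus estimated at 300 nM, with a range from 80 nM to 1200 nM.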

Compound 4, half-maximal effective concentration: 60 nM
Beside the measured number, compound 4's estimate is 5.0-fold (0.70 log units) above it; the whole stated range lies above it.
By their numbers in this assay, from the lowest: compound 4; then compound 3; then compounds 1 and 2 (each within the scatter of the next).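

In this assay, the drop seen earlier with 2-cyanophenyl recurs with 4-cyanophenyl in the same place, on a saturated chain carbon bound to an oxygen on a saturated carbon (a 33-fold lower number from compound 2 to compound 4 (1.52 log units; beyond the scatter)), so it is not tied to a single arrangement of the nitrile on the ring. Among these compounds, the first direct comparison of the two cyanophenyl groups gives a modest step that is printed as just beyond the scatter (a 2.1-fold lower number from compound 3 to compound 4 (0.33 log units; beyond the scatter)), much smaller than either step away from the (3,5-dimethyl-1H-pyrazol-1-yl)methyl group of compound 2, so the choice between these two nitrile arrangements counts for less here than the exchange of that group for a cyanophenyl. Nothing in the available data gives a reason for either step.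

The compounds shown leave open whether the nitrile contributes at all, since a plain phenyl without it would separate its share from that of the benzene ring itself. Also open, from the compounds shown here alone, is how far this position tolerates other changes, such as a carboxylic acid or an amine in place of the nitrile, or a longer chain in place of the 4-cyanobenzyl link to the ring.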